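A few compounds are considered here, and "the series" means these few. Any claim that something is new, unique, unknown or untested is made for them only; others in the source may bear on it.

The measured compounds in a functional assay on SK-BR-3 cells (Homo sapiens) for antiproliferative activity, read by MTT assay, with a stated time of 72 h; on this read-out higher numbers stand for weaker inhibition and lower numbers for stronger inhibition:
Compound 1, `CCN1CCN(c2cc(C)c3cc(NC(=O)c4cccc(C)c4)ccc3n2)CC1`, gives 13700 nM.
Compound 2, `Cc1cc(N(C)C)nc2ccc(NC(=O)c3ccc(Cl)c(Cl)c3)cc12`, gives only the assay limit > 50000 nM, not a number.
Compound 3, `Cc1cc(N2CCN(C(C)C)CC2)nc2ccc(NC(=O)c3ccc(Cl)c(Cl)c3)cc12`, gives 6680 nM.

Compound 1 thus stands highest of the two numbers shown; the nearest, compound 3, sits lower by a step that goes beyond the scatter. Within the data shown here, the one step measured between close neighbours, an at least 7.4-fold lower number from compound 2 to compound 3 (0.87 log units; beyond the scatter), concerns the amine on the shared core, and its size is known only as a lower bound, since compound 2 sits at the limit of > 50000 nM in this assay, at which 1 of the 3 values shown sits.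

Compound 4, `CCN1CCN(c2cc(C)c3cc(NC(=O)c4cc5ccccc5[nH]4)ccc3n2)CC1`, is not yet measured. It differs from compound 1 by 1H-indol-2-yl in place of 3-methylphenyl on a carbonyl carbon. No measured step touches that part of the structure, so the change from compound 1 to compound 4 has no direct precedent among these compounds. With nothing to push the expectation either way, the step of a 1.2-fold lower number from compound 1 to compound 4 (0.10 log units; within the scatter) is expected to stay within the scatter. Compound 4 is therefore estimated at 11000 nM in this assay, with a range from 3000 nM to 40000 nM.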

Compound 4, half-maximal inhibitory concentration: 2550 nM
Compound 4: the middle estimate sits 4.3-fold (0.63 log units) above what was measured, and the stated range ends above it.
By their numbers in this assay, from the lowest: compound 4; then compound 3; then compound 1. At a limit, above all of these: compound 2.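

A step of a 5.4-fold lower number from compound 1 to compound 4 (0.73 log units; beyond the scatter) shows, for the first time among these compounds, that the group on the carbonyl carbon moves the number in this assay as the amine on the shared core does. The entering 1H-indol-2-yl differs from 3-methylphenyl in several counted features at once, including a five-membered aromatic ring with 1 hetero atom and 1 hydrogen-bond donor, and this single step does not separate them. Nothing measured here gives a cause for the step.

The compounds shown leave open whether the ring's hydrogen-bond donor matters, a question that 1-methyl-1H-indol-2-yl or benzofuran-2-yl on the same carbonyl carbon would address. They also leave open whether 1H-indol-2-yl would give a similar step alongside 4-isopropylpiperazin-1-yl on the shared core.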